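From 4-Ethylphenyl to 3,5-Dimethylphenyl on a Sulfur

The source may hold more compounds than are shown below. What is called first, only, known or untested is meant among the compounds shown, and "the series" means these compounds.

Within the data shown here, in a functional assay on HeLa cells (Homo sapiens) for antiproliferative activity, read by CCK-8 assay, with a stated time of 72 h (on this read-out lower numbers stand for stronger inhibition and higher numbers for weaker inhibition), compound 1 `CCc1ccc(SCc2ccc(C(=O)Nc3ccccc3N)cc2)cc1` gives 3800 nM and holds the higher of the two numbers so far, which makes it the weaker of the pair. Compound 2 `Nc1ccccc1NC(=O)c1ccc(CSc2nccc(C(F)(F)F)n2)cc1` reaches 1140 nM in this assay and its gap to compound 1 lies beyond the usual scatter. Compound 3 `Cc1cc(C)cc(SCc2ccc(C(=O)Nc3ccccc3N)cc2)c1` has not yet been measured. It keeps the core of compound 1 and carries 3,5-dimethylphenyl in place of 4-ethylphenyl on a sulfur with the same atoms joined differently. Among the measured compounds shown here, no two measured compounds differ in one place only, so nothing shows directly what this swap does. No step beyond the scatter is therefore expected in this assay and the estimated step of a 1.2-fold lower number from compound 1 to compound 3 (0.07 log units; within the scatter) should be small. For compound 3 the estimate is 3200 nM with an expected range from 1300 nM to 8000 nM in this test.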

Compound 3, half-maximal inhibitory concentration: 2090 nM
Compound 3: middle estimate off by 1.5-fold (0.19 log units), on the high side; measured number inside the range.
By their numbers in this assay, from the lowest: compounds 2, 3 and 1 (each within the scatter of the next, the first and the last beyond it).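

In this assay, among these compounds, 3,5-dimethylphenyl in place of 4-ethylphenyl on a sulfur gives a 1.8-fold lower number from compound 1 to compound 3 (0.26 log units; within the scatter), the first direct reading of a single change at this position. The two groups are built from the same number of carbon atoms, arranged as two methyl groups in one and a single ethyl chain in the other, and this rearrangement does not separate the two compounds beyond the normal spread of repeat measurements. No measured property of either group is available to bear on this result.

Still open, on these data alone, is whether a step beyond the scatter appears at this position when the phenyl ring on the sulfur carries something other than these small carbon groups. A methoxy group, an amine or a carboxylic acid there would test this.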